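Swapping a Methoxy Group for a Longer Ether Chain

The source may report more compounds than this note shows. Statements on the series, on what has been measured and on what is new or still open speak of the compounds shown alone.

In a functional assay on SMOV2 cells (Homo sapiens) for antiproliferative activity, read by sulforhodamine B assay, with a stated time of 3 days (on this read-out lower numbers stand for stronger inhibition of growth and higher numbers for weaker inhibition of growth), compound 1 (`O=c1[nH]c2ccc(-c3csc(-c4ccc(F)c(C(F)(F)F)c4)n3)cc2o1`) shows a result of > 50000 nM that is a limit of the assay and not a number. Within the data shown here, compound 2 (`COc1cc(F)ccc1-c1nc(-c2ccc3[nH]c(=O)oc3c2)cs1`) gives 5700 nM as the only actual number so far, which makes it the single reference point for what follows.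

Compound 3 (`COCCOCc1cc(F)ccc1-c1nc(-c2ccc3[nH]c(=O)oc3c2)cs1`) is compound 2 with (2-methoxyethoxy)methyl in place of methoxy on an aromatic carbon, a place that is ortho to a large group and meta to a fluoro group. Among the measured compounds shown here, no two measured compounds differ in one place only, so no measured step can guide the forecast directly.

In this assay the expected result is a slight weakening of growth inhibition, and the estimated step (a 1.6-fold higher number from compound 2 to compound 3 (0.20 log units; within the scatter)) may stay within the usual scatter of repeated measurements. Compound 1 reached a limit (> 50000 nM) and so a much larger loss cannot be ruled out. For compound 3 the estimated value is 9000 nM (expected range 2500 nM to 35000 nM).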

Compound 3, concentration for 50% growth inhibition: 2 nM
The estimate for compound 3 lay 4500-fold (3.65 log units) above the measured number; the whole stated range lies above it.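

In this assay, putting (2-methoxyethoxy)methyl in place of methoxy, on the aromatic carbon that is ortho to a large group and meta to a fluoro group, brings a 2900-fold lower number from compound 2 to compound 3 (3.45 log units; beyond the scatter) and turns a modest result into a very strong one. This position is therefore far from a silent spot on the molecule: the group placed there can decide most of the growth inhibition seen in these cells, and a chain of 6 heavy atoms is accepted there with no loss. The swap changes several things at once, going from 2 heavy atoms to 6 and from 1 hydrogen-bond acceptor to 2, so this single step cannot show which of these differences matters.

A plain propyl or butyl chain at the same carbon would test whether the chain alone is enough, while a chain ending in an amine or a carboxylic acid would test how much its far end can vary. Nothing in the data shown explains why this step is so large.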